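Exchanging the aryl group on the shared core

The source may hold more compounds than are shown below. What is called first, only, known or untested is meant among the compounds shown, and "the series" means these compounds.

Of the compounds shown here, two with one shared core have been tested in a functional assay on HT-29 cells (Homo sapiens) for inhibition, read by sulforhodamine B assay, with a stated time of 48 h, tested at 10 uM; on this read-out higher numbers stand for more inhibition at the one concentration tested (going by the name of the read-out) and lower numbers for less inhibition. Compound 1 `c1ccc2c(-c3cn4ccnc4c(-c4ccc5ncn(C6CCCCC6)c5c4)n3)cccc2c1` carries a naphthalen-1-yl group and in this assay gives 4.11%. Compound 2 `Clc1ccc(-c2cn3ccnc3c(-c3ccc4ncn(C5CCCCC5)c4c3)n2)cc1` carries a 4-chlorophenyl group at the same position and gives 16.4%. Within the data shown here, the single measured step, a number 12.3 percentage points higher from compound 1 to compound 2 (beyond the scatter), is what separates them. On the two numbers at hand compound 2 stands highest, with compound 1 a step below it, beyond the scatter.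

The next compound, compound 3 `FC(F)(F)c1cccc(-c2cn3ccnc3c(-c3ccc4ncn(C5CCCCC5)c4c3)n2)c1`, differs from compound 2 in one place: 3-(trifluoromethyl)phenyl in place of 4-chlorophenyl on an aromatic carbon. Among the measured compounds shown here, no measured step covers this exact exchange. The step from compound 1 to compound 2 concerns a different group and serves only as a loose guide, showing that changing the group at this position can shift the read-out modestly. Both measured values are low, and a large rise from such a starting point is not supported by anything measured. For compound 3 the expected step is a number 4.4 percentage points lower from compound 2 to compound 3 (within the scatter), small enough that it may lie within the scatter. Compound 3 is therefore estimated at 12%, with a likely range from 0% to 30%.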

Compound 3, a percentage reported as inhibition, at one concentration (the size of the read-out at that concentration, not a potency): 6.41%
Compound 3: the middle estimate sits 5.6 percentage points above what was measured; low and high end bracket the measured number.
By their numbers in this assay, from the lowest: compounds 1, 3 and 2 (each within the scatter of the next, the first and the last beyond it).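

Exchanging 4-chlorophenyl for 3-(trifluoromethyl)phenyl gives a number 10 percentage points lower from compound 2 to compound 3 (within the scatter) in this assay, and exchanging naphthalen-1-yl for the same group gives a number 2.3 percentage points higher from compound 1 to compound 3 (within the scatter) in that assay, so compound 3 cannot be told apart from either of the other two compounds. Among these compounds, the only step beyond the scatter therefore remains the one between compound 1 and compound 2, and the third aryl group adds no clear separation at this position, where all three numbers stay low at the one concentration tested. Nothing available explains why these groups give the numbers they do.

The exchange between compound 2 and compound 3 alters both the atoms on the ring and where they sit, so 3-chlorophenyl or 4-(trifluoromethyl)phenyl would be needed to separate those two differences. All three groups at this position are aromatic and built on rings of carbon only, which leaves open how the read-out would respond to an amine, a carboxylic acid or a saturated ring such as morpholine in their place.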